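The compounds below may be only part of what the source reports. "The series", "measured", "known", "first", "only" and "open" are said of these compounds alone.

Measured compounds: compound 1 `Nc1n[nH]c2cc(-c3ccccn3)[nH]c(=O)c12` gives 3%; compound 2 `Nc1n[nH]c2cc(CC3CCNCC3)[nH]c(=O)c12` gives -56%; compound 3 `Cc1cc2[nH]nc(N)c2c(N2CCCCC2)n1` gives 43% in an assay on isolated protein for inhibition of protein kinase C zeta type (Homo sapiens), read by mobility shift assay, tested at 30 uM; a lower number here means less inhibition, a higher number more inhibition at the concentration tested (going by the name of the read-out).

Among these three numbers compound 3 stands highest in this assay; the nearest is compound 1, lower by a margin beyond the scatter, and the furthest is compound 2, far lower still. Compound 4 `Cc1cc2c(c(N)nn2C)c(N2CCCCC2)n1` differs from compound 3 by methyl in place of hydrogen on an aromatic nitrogen. Among the compounds with values here, no pair of measured compounds shows this change, so its effect is unknown here. The expected step of a number 18 percentage points lower from compound 3 to compound 4 (beyond the scatter) is a small decrease that may not exceed the scatter, because compound 3 sits at 43% and no measured change offers a reason to expect a rise. Compound 4 is estimated at 25%, with a range from 0% to 50%.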

Compound 4, a percentage reported as inhibition, at one concentration (the size of the read-out at that concentration, not a potency): -152%
Compound 4: the middle estimate sits 177 percentage points above what was measured, and the stated range ends above it.
By their numbers in this assay, from the lowest: compound 4; then compound 2; then compound 1; then compound 3.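

Methyl in place of hydrogen on the aromatic nitrogen of the five-membered ring gives a number 195 percentage points lower from compound 3 to compound 4 (beyond the scatter) in this assay and so shows that this position is far from indifferent to substitution. Within the data shown here, the earlier compounds offered no pair that tested this nitrogen, and this large step is the only reading of it. Nothing at hand explains the size of the step. Going by these compounds, whether an ethyl group or a hydroxyethyl chain on that nitrogen would behave like methyl stays open. So does whether the same change acts alike on the core of compound 1.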